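Shortening a methoxy-ended chain on a shared core

A few compounds are considered here, and "the series" means these few. Any claim that something is new, unique, unknown or untested is made for them only; others in the source may bear on it.

Compound 1 `COCCCOc1cc(C)c(-c2cccc(COc3ccc(OCC(=O)O)c(F)c3)c2)c(C)c1` carries a three-carbon methoxy-ended chain on an oxygen of its aromatic ring. In a physicochemical assay for lipophilicity, using the shake flask method, in phosphate buffer, measured as octanol-water partition, with a stated time of 24 h, at pH 7.4, tested at 100 uM (a higher number here means a more lipophilic compound, a lower number a more polar compound), compound 1 has "not determined" (no result reported), so it stands without a number of its own. Compound 2 `Cc1cc(OC(C)C)cc(C)c1-c1cccc(COc2ccc(OCC(=O)O)c(F)c2)c1` likewise has "not determined" (no result reported) in this assay. Within the data shown here, the only number comes from compound 3 `Cc1cc(OCCCS(C)(=O)=O)cc(C)c1-c1cccc(COc2ccc(OCC(=O)O)c(F)c2)c1`, which in this assay gives 1.81. Compound 4 `COCCOc1cc(C)c(-c2cccc(COc3ccc(OCC(=O)O)c(F)c3)c2)c(C)c1` differs from compound 1 in one place: methoxy in place of methoxymethyl on a saturated chain carbon, two bonds along the chain from an oxygen on an aromatic ring. Among the measured compounds shown here, since compound 1 carries no number, no measured step can anchor the change. In this assay a small step is expected, pointing toward a lower value for compound 4 than compound 1 would show, and it may not reach beyond the scatter of repeated runs. Because compound 3 gives 1.81 as the nearest measured relative on the same core, compound 4 is expected to come out near 2.4, estimated to fall between 1.7 and 3.1.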

Compound 4, distribution coefficient: 3.15
Estimate against measurement, compound 4: 0.75 log units below, and the stated range ends below it.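

In this assay there is now a measured step at this place on the shared core, a number 1.34 log units higher from compound 3 to compound 4 (beyond the scatter) with methoxy in place of (methylsulfonyl)methyl on a saturated chain carbon. Among these compounds, for this pair, then, the group at the end of the chain can move the reading well past what repeated runs would scatter, something the single earlier number could not show. The step from compound 1 to compound 4 cannot be read, as compound 1 has no number, and no measurement shown here explains the size of the step that can be read.

Still open, on these data alone, is how a chain ending in a hydroxyl group or an amine would read at this place. Also open, as far as these compounds go, is what a longer chain with the same methoxy end would give.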